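The compounds below may be only part of what the source reports. "The series", "measured", "known", "first", "only" and "open" are said of these compounds alone.

Measured so far:
compound 1, `CC1=NN(C(=O)/C=C/c2ccccc2)C(c2ccccc2O)C1`, gives 29000 nM in a functional assay on HepG2 cells (Homo sapiens) for cytotoxicity, read by MTT assay, with a stated time of 48 h; a higher number here means a weaker inhibitor, a lower number a stronger inhibitor;
compound 2, `CC1=NN(C(=O)CN2CCN(C(=O)OC(C)(C)C)CC2)C(c2ccccc2O)C1`, gives 5000 nM in this assay;
compound 3, `O=C(c1ccccc1)N1N=C(c2cc3ccccc3oc2=O)CC1c1ccccc1`, gives 36600 nM in this assay.

Compound 3 and compound 1 lie within the scatter of each other, so the two cannot be told apart, while compound 2 sits clearly lower than compound 3. Compound 4, `CC1CCCCN1CC(=O)N1N=C(c2cc3ccccc3oc2=O)CC1c1ccccc1`, has not been measured. It differs from compound 3 in one place: (2-methylpiperidin-1-yl)methyl in place of phenyl on a carbonyl carbon. Within the data shown here, no step between two measured compounds shows this change, so the expected step of a 2.4-fold lower number from compound 3 to compound 4 (0.39 log units; beyond the scatter) in this assay is a guess: a modest fall in the number, somewhat beyond the scatter, is expected. Compound 4 is therefore estimated at 15000 nM, with a range from 5000 nM to 45000 nM.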

Compound 4, half-maximal inhibitory concentration: "not active" (no number reported)
For compound 4 the study gives words and no number, and the estimate cannot be compared.
By their numbers in this assay, from the lowest: compound 2; then compounds 1 and 3 (each within the scatter of the next).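

Among these compounds, compound 4 is reported only in words, so no step from compound 3 to compound 4 can be read. No supporting evidence bears on this result. The compounds shown leave open how far in this assay the number moves with (2-methylpiperidin-1-yl)methyl in place of phenyl.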